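Working notes: from compound 2 to compound 3

This account rests on a few compounds, and the source may have more. Where it says the series, first, only, none or still open, it means among the compounds named here.

Measured in an ADME assay on MDCK-II cells (Canis lupus familiaris) for permeability; on this read-out higher numbers stand for higher permeability and lower numbers for lower permeability:
- compound 1 `CC(C)Oc1cc(Oc2ccc(S(C)(=O)=O)cc2)cc(-c2cncc(=O)[nH]2)c1`: 94 10^-6 cm/s
- compound 2 `Cc1cc(=O)[nH]c(-c2cc(Oc3ccc(S(C)(=O)=O)cc3)cc(OC(C)C)c2)n1`: 4.8 10^-6 cm/s

Among the measured compounds shown here, compound 2, at 4.8 10^-6 cm/s, holds the lower of the two numbers so far. The next compound to be read is compound 3 `CCc1cnc(-c2cc(Oc3ccc(S(C)(=O)=O)cc3)cc(OC(C)C)c2)[nH]c1=O`, and the change leading to it is a group of 9 heavy atoms (6 carbon, 2 nitrogen, 1 oxygen; one six-membered aromatic ring with 2 hetero atoms) in place of a group of 8 heavy atoms (5 carbon, 2 nitrogen, 1 oxygen; one six-membered aromatic ring with 2 hetero atoms), on an aromatic carbon. The rest of the structure stays the same, including the isopropoxy group.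

For the measured compounds named here, only one measured step bears on this change: a 20-fold lower number from compound 1 to compound 2 (1.29 log units; beyond the scatter). It is large and beyond the scatter, and it also exchanges the group at this aromatic carbon. It shows that this assay can respond strongly to a change in this group, but it gives neither the size nor the direction for this new exchange. Going by the values given here, no measured compound isolates the added heavy atom. A small rise is therefore expected, with no firm expectation of a step beyond the scatter, and a wide range is kept open. The expected step is a 1.9-fold higher number from compound 2 to compound 3 (0.27 log units; within the scatter).

For compound 3 the estimate is 9 10^-6 cm/s, with an expected range from 3 10^-6 cm/s to 30 10^-6 cm/s.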

Compound 3, apparent permeability: 4 10^-6 cm/s
Compound 3: middle estimate off by 2.3-fold (0.35 log units), on the high side; measured number inside the range.
By their numbers in this assay, from the lowest: compounds 3 and 2 (each within the scatter of the next); then compound 1.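

In this assay, putting the group of 9 heavy atoms in place of the group of 8 heavy atoms on this aromatic carbon gives a 1.2-fold lower number from compound 2 to compound 3 (0.08 log units; within the scatter), so this exchange does not separate compound 3 from compound 2 on this read-out. Against compound 1, the same position gives a 24-fold lower number from compound 1 to compound 3 (1.37 log units; beyond the scatter), a large step of the same kind as a 20-fold lower number from compound 1 to compound 2 (1.29 log units; beyond the scatter), so two different groups now stand apart from the group of compound 1, while the numbers of compound 2 and compound 3 lie within the scatter of each other. No measurement shown offers an explanation for either the large steps from compound 1 or the absence of a clear step from compound 2 to compound 3.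

Still open, on these data alone, is how this read-out responds to a longer chain, an amine or a carboxylic acid carried on the six-membered aromatic ring with 2 hetero atoms. Also open, as far as these compounds go, is whether these steps keep their size when the isopropoxy group, unchanged across all three compounds, is replaced by another group.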